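The compounds below may be only part of what the source reports. "The series", "measured", "known", "first", "only" and "open" are said of these compounds alone.

Measured compounds:
compound 1, `CSc1ccccc1Nc1nc2c(Nc3ccc(C(F)(F)F)cc3)ncnc2s1`: 43 nM
compound 2, `O=C(c1ccc(Nc2ncnc3sc(Nc4c(Cl)cccc4Cl)nc23)cc1)N1CCCC1`: > 5000 nM
compound 3, `FC(F)(F)c1ccc(Nc2nc(N3CCC3)nc3sc(Nc4c(Cl)cccc4Cl)nc23)cc1`: 59 nM

These three share a core and were tested in a functional assay on HEK293 cells for antagonist activity at transient receptor potential cation channel subfamily V member 1 (Homo sapiens), read by calcium flux; a lower number here means a stronger inhibitor, a higher number a weaker inhibitor. Compound 1 gives 43 nM in this assay. Compound 3 gives 59 nM, and the values of compound 3 and compound 1 lie within the scatter of each other, so no order between them can be read. For compound 2 the record is the limit of > 5000 nM in this assay, at which 1 of the 3 values shown sits, rather than a number. Compound 3 therefore stands with compound 1 among the two compounds that yield a number at all.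

Compound 4, `CCN(CC)c1nc(Nc2ccc(C(F)(F)F)cc2)c2nc(Nc3c(Cl)cccc3Cl)sc2n1`, is not yet measured. It differs from compound 3 in one place: diethylamino in place of azetidin-1-yl on an aromatic carbon. Among the compounds with values here, no measured pair in this set follows the same change, so the expectation rests on the similarity of the two groups and on the fact that compound 3 already gives a number. The step from compound 3 to compound 4 is expected to be a 1.4-fold higher number from compound 3 to compound 4 (0.13 log units; within the scatter), that is, none beyond the scatter. Compound 4 is expected to give about 80 nM in this assay, within a range from 25 nM to 250 nM.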

Compound 4, half-maximal inhibitory concentration: 48 nM
Beside the measured number, compound 4's estimate is 1.7-fold (0.22 log units) above it; the measured number falls inside the stated range.
By their numbers in this assay, from the lowest: compounds 1, 4 and 3 (each within the scatter of the next). At a limit, above all of these: compound 2.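

In this assay, the aromatic carbon between two ring nitrogen atoms carries either diethylamino or azetidin-1-yl with no change that can be read: a 1.2-fold lower number from compound 3 to compound 4 (0.09 log units; within the scatter). Within the data shown here, this is the first pair here that differs in one place, and it shows that replacing the four-membered ring with an open diethylamino group at this carbon leaves the number within the scatter. Nothing shown accounts for this step or bears on its cause.

From the compounds shown here alone, the two groups compared are both dialkylamino-type substituents attached through nitrogen, so it stays open how a morpholine ring, a primary amine or a carboxylic acid would behave at this carbon. Also open, going by these compounds, is how far a longer chain on the nitrogen could go before the number moves beyond the scatter.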